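From a 4-Bromophenyl to a 3,4-Dichlorophenyl Group

This account rests on a few compounds, and the source may have more. Where it says the series, first, only, none or still open, it means among the compounds named here.

Compound 1 `Nc1cc(C2CCCC2)nc2ccc(NC(=O)/C=C/c3ccc(C(F)(F)F)cc3)cc12`: 0.8 nM
Compound 2 `CCCc1cc(N2CCCC2)c2cc(NC(=O)/C=C/c3ccc(C(F)(F)F)cc3)ccc2n1`: 17 nM
Compound 3 `CCCc1cc(N)c2cc(NC(=O)/C=C/c3ccc(Br)cc3)ccc2n1`: 4 nM

These three compounds were tested in an assay on isolated protein for displacement of a labelled ligand from melanin-concentrating hormone receptor 1 (Homo sapiens); on this read-out lower numbers stand for stronger inhibition and higher numbers for weaker inhibition. Among them compound 3 stands in the middle: compound 2 shows a higher number and compound 1 a lower one, and both gaps lie beyond the usual scatter of this assay.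

Compound 4 `CCCc1cc(N)c2cc(NC(=O)/C=C/c3ccc(Cl)c(Cl)c3)ccc2n1` is the next compound, not yet measured. It differs from compound 3 in one place: 3,4-dichlorophenyl in place of 4-bromophenyl on a double-bonded chain carbon bound to a double-bonded chain carbon. For the measured compounds named here, no measured pair shows this exact change, so the size of the step cannot be read from the data.

The expectation is a step from compound 3 to compound 4 of a 1.3-fold lower number from compound 3 to compound 4 (0.12 log units; within the scatter), likely within the scatter. Compound 4 is therefore estimated at 3 nM, with a range from 1 nM to 9 nM.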

Compound 4, half-maximal inhibitory concentration: 60 nM
For compound 4 the middle estimate is 20-fold (1.30 log units) below the measured one; the whole stated range lies below it.
By their numbers in this assay, from the lowest: compound 1; then compound 3; then compound 2; then compound 4.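

In this assay, 3,4-dichlorophenyl in place of 4-bromophenyl brings a 15-fold higher number from compound 3 to compound 4 (1.18 log units; beyond the scatter), so the exact halogens on this ring matter a great deal on the shared core. For the compounds shown here, the earlier compounds included no pair differing in one place, so this is the first direct reading of a single change here. Nothing measured here gives a reason for this step.

From the compounds shown here alone, it remains open whether the loss of bromine or the arrival of the second chlorine counts more; a 4-chlorophenyl group would separate the two. Also open, going by these compounds, is how a methoxy group on this ring would compare.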